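One Ring Swapped on a Shared Core

The compounds below may be only part of what the source reports. "The series", "measured", "known", "first", "only" and "open" are said of these compounds alone.

Within the data shown here, compound 1 (`CN(c1ncco1)c1cnc(NCc2c(F)ccc3c2CCO3)n2cnnc12`) is the only member of this small series with a number so far. Among the measured compounds shown here, in an ADME assay on the whole organism (Rattus norvegicus) for pharmacokinetics (on this read-out lower numbers stand for slow clearance and higher numbers for fast clearance), compound 1 gives 29 mL/min/kg as the sole measured value, so it cannot yet be ranked against any neighbour. Compound 2 (`O=C1c2ccccc2CN1c1cnc(NCc2c(F)ccc3c2CCO3)n2cnnc12`) stands at "not determined" (no result reported) in this assay and compound 3 (`Cc1ncccc1-c1cnc(NCc2c(F)ccc3c2CCO3)c2cn[nH]c(=O)c12`) stands at "not determined" (no result reported) there, so neither offers a comparison. Compound 4 (`CN(c1ccn(C)n1)c1cnc(NCc2c(F)ccc3c2CCO3)n2cnnc12`) keeps the shared core of compound 1. The change (1-methyl-1H-pyrazol-3-yl in place of 1,3-oxazol-2-yl on a nitrogen on an aromatic ring) puts 1-methyl-1H-pyrazol-3-yl in place of 1,3-oxazol-2-yl on a nitrogen on an aromatic ring. For the measured compounds named here, no measured pair shows what such a swap does, so the data favour neither a rise nor a fall. The best available anchor is therefore compound 1 at 29 mL/min/kg on this scale. The expected step of no change at the digits printed from compound 1 to compound 4 (within the scatter) is estimated to stay within the usual scatter, with no direction favoured. Compound 4 is expected at 29 mL/min/kg in this assay (estimated range 13 mL/min/kg to 60 mL/min/kg).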

Compound 4, clearance: 29 mL/min/kg
Estimate against measurement, compound 4: no gap at the digits printed; the measured number falls inside the stated range.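

In this assay, among these compounds, putting 1-methyl-1H-pyrazol-3-yl in place of 1,3-oxazol-2-yl on a nitrogen on an aromatic ring gives the first measured step: no change at the digits printed from compound 1 to compound 4 (within the scatter). At this place, then, these two five-membered aromatic rings cannot be told apart by clearance in the rat, a reading that a single compound could not give. Nothing measured here bears on why the two groups read alike.

Among the compounds shown here, no step involving compound 2 or compound 3 can be read, since neither has a number. On these data alone, it remains open whether clearance would also hold with something other than a five-membered aromatic ring on that nitrogen, such as a morpholine, a carboxylic acid or a longer chain like butyl.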